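Fluoro on the benzyl ring of compound 1

The source may hold more compounds than are shown below. What is called first, only, known or untested is meant among the compounds shown, and "the series" means these compounds.

Measured in a functional assay on J774.A1 cells (Mus musculus) for inhibition, read by immunoassay, with a stated time of 12 h, tested at 30 uM; on this read-out higher numbers stand for more inhibition at the one concentration tested (going by the name of the read-out) and lower numbers for less inhibition:
- compound 1 `O=C1CC(c2ccccc2OCc2ccccc2)Oc2ccccc21`: 91.5%
- compound 2 `CC(C)c1ccc(COc2ccccc2C2CC(=O)c3ccccc3O2)cc1`: 91.7%
- compound 3 `COCOc1ccccc1C1CC(=O)c2ccccc2O1`: 33.3%

Compound 1 stands second highest of the three numbers; its nearest neighbour is compound 2, with a number 0.2 percentage points higher from compound 1 to compound 2 (within the scatter), and its furthest is compound 3, with a number 58.2 percentage points lower from compound 1 to compound 3 (beyond the scatter). Among the measured compounds shown here, compound 2 to compound 3 shows the same kind of gap, a number 58.4 percentage points lower from compound 2 to compound 3 (beyond the scatter), so the only large steps in the set belong to the exchange of the benzyl-type group for methoxymethyl and not to substitution on the benzyl ring itself.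

Compound 4 `O=C1CC(c2ccccc2OCc2ccc(F)cc2)Oc2ccccc21` is not yet measured. It differs from compound 1 by fluoro in place of hydrogen on an aromatic carbon, para to a large group. For the measured compounds named here, the one measured step that bears on this change is the placing of isopropyl on the same aromatic carbon, a number 0.2 percentage points higher from compound 1 to compound 2 (within the scatter), which stayed within the scatter. A single fluorine at the same site is therefore expected to give no step beyond the scatter in this assay, a number 1.5 percentage points lower from compound 1 to compound 4 (within the scatter). Compound 4 is estimated at 90%, with a range from 78% to 97%.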

Compound 4, a percentage reported as inhibition, at one concentration (the size of the read-out at that concentration, not a potency): 42.1%
For compound 4 the middle estimate is 47.9 percentage points above the measured one, and the stated range ends above it.
By their numbers in this assay, from the lowest: compounds 3 and 4 (each within the scatter of the next); then compounds 1 and 2 (each within the scatter of the next).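

In this assay this aromatic carbon of the benzyl ring proves sensitive to what is placed on it: fluoro in place of hydrogen gives a number 49.4 percentage points lower from compound 1 to compound 4 (beyond the scatter), and fluoro in place of isopropyl gives a number 49.6 percentage points lower from compound 2 to compound 4 (beyond the scatter), so the silence of the isopropyl step does not extend to every group at this carbon. Compound 4 stands with the methoxymethyl compound, at a number 8.8 percentage points higher from compound 3 to compound 4 (within the scatter), and not with the other two benzyl-type compounds, so the benzyl-type group alone does not secure the high read-out. No evidence in hand speaks to what lies behind this result.

Going by these compounds, whether the loss is particular to fluoro stays open; chloro, methyl or methoxy on the same carbon would show which of fluoro and isopropyl is the exception. Also open, on these data alone, is whether fluoro on the other carbons of the benzyl ring gives a step of the same size.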